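Swapping the Thiadiazole for a Bromothiophene in Compound 1

This account rests on a few compounds, and the source may have more. Where it says the series, first, only, none or still open, it means among the compounds named here.

Measured so far:
Compound 1, `CC(C)c1nnsc1C[S+]([O-])C(c1ccccc1)c1ccccc1`: 69100 nM
Compound 2, `Cc1ccc(C(c2ccc(C)cc2)[S+]([O-])Cc2cccs2)cc1`: 5800 nM

In an assay on HEK293 cells for inhibition of sodium-dependent dopamine transporter (Homo sapiens), read by scintillation counting, with stated times of 5 min and 1 min (a lower number here means a stronger inhibitor, a higher number a weaker inhibitor), compound 1 gives the higher of the two numbers, and the gap to compound 2 lies beyond the scatter. Compound 3, `[O-][S+](Cc1ccsc1Br)C(c1ccccc1)c1ccccc1`, differs from compound 1 by 2-bromothiophen-3-yl in place of 4-isopropyl-1,2,3-thiadiazol-5-yl on a saturated chain carbon bound to a sulfur. For the measured compounds named here, no measured pair shows this change, so the size of the step is open. Compound 2 carries a thiophene-bearing chain and gives the lower number, which suggests a move toward lower numbers here. The step of a 5.8-fold lower number from compound 1 to compound 3 (0.76 log units; beyond the scatter) is expected to be large. Compound 3 is estimated at 12000 nM, within 3000 nM to 45000 nM.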

Compound 3, half-maximal inhibitory concentration: 29300 nM
The estimate for compound 3 lay 2.4-fold (0.39 log units) below the measured number; the measured number falls inside the stated range.
By their numbers in this assay, from the lowest: compound 2; then compound 3; then compound 1.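

In this assay, placing 2-bromothiophen-3-yl instead of 4-isopropyl-1,2,3-thiadiazol-5-yl on the saturated chain carbon bound to a sulfur gives a 2.4-fold lower number from compound 1 to compound 3 (0.37 log units; beyond the scatter) as a modest step. This shows that the number responds to a change at this position alone, with the rest of compound 1 held constant. Nothing available here explains the step. Whether the bromine or the thiophene ring accounts for it remains open. So does how an unsubstituted thiophen-3-yl or a 2-chlorothiophen-3-yl group would read at this position.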